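The source may report more compounds than this note shows. Statements on the series, on what has been measured and on what is new or still open speak of the compounds shown alone.

Series in a functional assay on NCI-H460 cells (Homo sapiens) for inhibition, with a stated time of 72 h; a lower number here means a stronger inhibitor, a higher number a weaker inhibitor:

compound 1 `COc1ccc(S(=O)(=O)N2CCc3cccc(-c4ccc(N)cc4)c32)cc1`: 288 nM
compound 2 `COc1ccc(S(=O)(=O)N2CCc3cccc(-c4ccc([N+](=O)[O-])cc4)c32)cc1`: 53.1 nM
compound 3 `COc1ccc(S(=O)(=O)N2CCc3cccc(-c4ccc(N(C)C)cc4)c32)cc1`: 556 nM

Compound 2 holds the lowest number of the three, at 53.1 nM, and both gaps to it lie beyond the scatter. One is a 5.4-fold lower number from compound 1 to compound 2 (0.73 log units; beyond the scatter), the other 10-fold higher number from compound 2 to compound 3 (1.02 log units; beyond the scatter). The remaining step, a 1.9-fold higher number from compound 1 to compound 3 (0.29 log units; within the scatter), lies within the scatter, so the amino and dimethylamino compounds cannot be separated.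

The next compound is compound 4 `COc1ccc(S(=O)(=O)N2CCc3cccc(-c4ccncc4)c32)cc1`, which carries pyridin-4-yl in place of 4-nitrophenyl on an aromatic carbon of the shared core: pyridin-4-yl in place of 4-nitrophenyl on an aromatic carbon. Within the data shown here, no measured step exchanges this whole aromatic ring. All three keep the six-membered aromatic ring of carbon only and change just the group on it, so they bear on this change only indirectly. Compound 4 loses the nitro group, and the two compounds without it sit higher, as shown by a 5.4-fold lower number from compound 1 to compound 2 (0.73 log units; beyond the scatter) and a 10-fold higher number from compound 2 to compound 3 (1.02 log units; beyond the scatter). From the compounds shown here alone, on that basis a modest to large rise in this assay is expected, with wide uncertainty since the new ring is untested.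

The expected change is a 3.8-fold higher number from compound 2 to compound 4 (0.58 log units; beyond the scatter). For compound 4 the estimated value is 200 nM, within an expected range of 60 nM to 700 nM.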

Compound 4, half-maximal inhibitory concentration: 101 nM
Compound 4: the middle estimate sits 2.0-fold (0.30 log units) above what was measured; the range from low to high includes it.
By their numbers in this assay, from the lowest: compounds 2 and 4 (each within the scatter of the next); then compounds 1 and 3 (each within the scatter of the next).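

In this assay, replacing the whole 4-nitrophenyl ring with pyridin-4-yl at this position gives no readable change: a 1.9-fold higher number from compound 2 to compound 4 (0.28 log units; within the scatter). Among these four compounds, then, a number in this range does not depend on the nitro group or on a six-membered aromatic ring of carbon only, which the earlier compounds, all sharing that ring, could not show. The same replacement does separate from the two amine-bearing compounds, with a 2.9-fold lower number from compound 1 to compound 4 (0.46 log units; beyond the scatter) and a 5.5-fold lower number from compound 3 to compound 4 (0.74 log units; beyond the scatter), so compounds 2 and 4 form one group and compounds 1 and 3 another, with the amino and dimethylamino groups on the phenyl ring both going with the higher numbers.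

No data are available that explain this grouping. The compounds shown leave open whether the ring nitrogen of compound 4 matters and where it must sit, a question that unsubstituted phenyl and pyridin-3-yl at the same position would address, while 4-cyanophenyl would test whether another non-amine group on the phenyl ring also stays with compounds 2 and 4.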